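The source may hold more compounds than are shown below. What is called first, only, known or untested is meant among the compounds shown, and "the series" means these compounds.

Compounds measured in an assay on HEK293 cells with D(4) dopamine receptor (Homo sapiens) as the target, read by FLIPR; a higher number here means that more compound is needed for the effect, a lower number that less compound is needed:

- compound 1, `N#Cc1cccnc1N1CCN(Cc2nc3ccccc3[nH]2)CC1`, gives 13.9 nM
- compound 2, `c1cnc(N2CCN(Cc3nc4ccccc4[nH]3)CC2)nc1`, gives 44.8 nM
- compound 3, `C[C@H]1CN(c2ccccn2)CCN1Cc1nc2ccccc2[nH]1`, gives 52 nM

Compound 3 has the highest of the three numbers in this assay, meaning the most compound is needed. Compared with compound 2 its number is within the scatter, so the two cannot be told apart on these data. Compared with compound 1, which needs the least compound, the gap is beyond the scatter.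

For the measured compounds named here, the one change among the measured compounds, a 3.2-fold higher number from compound 1 to compound 2 (0.51 log units; beyond the scatter), swaps one group on a ring nitrogen for another. It says nothing about the change now considered.

Compound 4, `C[C@@H]1CN(c2ccccn2)CCN1Cc1nc2ccccc2[nH]1`, differs from compound 3 only in this way: the two compounds have the same atoms and bonds and differ only in configuration as drawn: 1 of 1 stereo elements differ; a stereocentre at a saturated ring carbon is drawn S in compound 3 and R in compound 4. Going by the values given here, no measured pair shows what flipping this stereocentre does, so nothing here indicates the direction or size of the step in this assay. Mirror-image forms of the same molecule can give similar or quite different numbers. The estimate for compound 4 is therefore centred near compound 3, 70 nM, with a wide range from 15 nM to 400 nM. This estimate corresponds to an expected step of a 1.3-fold higher number from compound 3 to compound 4 (0.13 log units; within the scatter).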

Compound 4, half-maximal effective concentration: 64 nM
For compound 4 the middle estimate is 1.1-fold (0.04 log units) above the measured one, and the stated range covers the measured number.
By their numbers in this assay, from the lowest: compound 1; then compounds 2, 3 and 4 (each within the scatter of the next).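

In this assay, turning the stereocentre at the saturated ring carbon from S to R gives a 1.2-fold higher number from compound 3 to compound 4 (0.09 log units; within the scatter), so the two mirror-image forms cannot be told apart on these numbers. For the compounds shown here, no earlier pair tested this position, and here its configuration, as far as this one pair shows, makes no clear difference to the amount of compound needed. The comparison bears on the stereocentre alone, because nothing else separates the pair: the fact that compounds 3 and 4 differ only in the configuration as drawn

The compounds shown leave open whether the same holds with a larger group at this ring carbon, such as an ethyl group, or with a 3-cyanopyridin-2-yl or pyrimidin-2-yl group on the ring nitrogen. They also leave open how either form compares with a ring that has no stereocentre at all.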